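The source may hold more compounds than are shown below. What is called first, only, known or untested is meant among the compounds shown, and "the series" means these compounds.

In an ADME assay on HEK293 cells (Homo sapiens) for cytotoxicity, read by CellTiter-Glo and resazurin assay, with a stated time of 72 h (a lower number here means that less compound is needed, a higher number that more compound is needed for the effect), three compounds have been measured so far:

- compound 1 `CC(C)N(Cc1cccc(OCCCCCC(=O)O)c1)C(=O)c1ccc(-c2ccoc2)cc1` gives > 26000 nM, which is a limit of the assay and not a number.
- compound 2 `Cc1nnc(-c2cccc(-c3ccc(C(=O)N(Cc4cccc(OCCCCCC(=O)O)c4)C(C)C)cc3)c2)o1` gives > 26000 nM, again a limit.
- compound 3 `CCOC(=O)CCCCCOc1cccc(CN(C(=O)c2ccc(-c3ccoc3)cc2)C(C)C)c1` gives > 26000 nM, also a limit.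

Compound 3 therefore stands at the ceiling of what this assay can report, where every value shown sits (the limit of > 26000 nM in this assay, at which 3 of the 3 values shown sit). Compound 4 `CCOC(=O)CCCCCOc1cccc(CN(C(=O)c2ccc(-c3cccc(C(F)(F)F)c3)cc2)C(C)C)c1` differs from it in one place: 3-(trifluoromethyl)phenyl in place of furan-3-yl on an aromatic carbon. Within the data shown here, two measured steps touch the same scaffold, a step that the two limits leave unreadable from compound 1 to compound 2 and a step that the two limits leave unreadable from compound 1 to compound 3, but both run between limits and so their size cannot be read. Among the measured compounds shown here, they give no hint of any step in this assay beyond the scatter, in either direction. The expectation for compound 4 is that it stays at the limit as well, so the estimated step that the limit leaves unreadable from compound 3 to compound 4 is essentially none. Compound 4 is estimated at 30000 nM, within a range from 15000 nM to 60000 nM.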

Compound 4, half-maximal effective concentration: > 26000 nM
Compound 4: only a limit was reported; the forecaster's own chance of this, stated with the estimate: 80%; the middle value lies beyond the limit too.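

The step from compound 3 to compound 4 cannot be read, as both compounds give only a limit of the assay and not a number: the limit of > 26000 nM in this assay, at which 4 of the 4 values shown sit. The compounds shown leave open whether, in this assay, any of them has an effect at some higher concentration.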